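Swapping the Tail on the Carbonyl Carbon of Compound 3

The compounds below may be only part of what the source reports. "The series", "measured", "known", "first", "only" and "open" are said of these compounds alone.

Compound 3 `Cc1nc(S(C)(=O)=O)ccc1Oc1ncnc(OC2CCN(C(=O)O[C@@H](C)C(F)(F)F)CC2)c1F` shows the smallest of the three numbers measured in a functional assay on isolated protein for inhibition of Glucose-dependent insulinotropic receptor (Rattus norvegicus), read by HTRF and cAMP accumulation; a lower number here means a smaller maximal response, a higher number a larger maximal response: compound 3 reaches 80%, compound 2 `Cc1nc(S(C)(=O)=O)ccc1Oc1ncnc(OC2CCN(C(=O)O[C@@H](C)CF)CC2)c1F` gives 84%, a gap within the usual scatter, and compound 1 `Cc1nc(S(C)(=O)=O)ccc1Oc1ncnc(OC2CCN(C(=O)OC(C)(C)C#N)CC2)c1F` gives 97%. Compound 4 `Cc1nc(S(C)(=O)=O)ccc1Oc1ncnc(OC2CCN(C(=O)SC(C)(C)C)CC2)c1F` differs from compound 3 by (tert-butyl)sulfanyl in place of 1-(trifluoromethyl)ethoxy on a carbonyl carbon. Among the compounds with values here, no measured step makes this exact exchange, but the two steps that alter this tail, a number 17 percentage points lower from compound 1 to compound 3 (beyond the scatter) and a number 13 percentage points lower from compound 1 to compound 2 (beyond the scatter), show that changes here move the maximal response only modestly. A step of similar size is therefore expected, probably upward, as the tail of compound 1, which gives 97%, resembles the entering group. The expected step is a number 8 percentage points higher from compound 3 to compound 4 (within the scatter). Compound 4 is estimated at 88%, with a range from 75% to 100%.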

Compound 4, largest response reached (reported as efficacy), in percent of the reference or control that the assay uses: 76%
Beside the measured number, compound 4's estimate is 12 percentage points above it, and the stated range covers the measured number.
By their numbers in this assay, from the lowest: compounds 4, 3 and 2 (each within the scatter of the next); then compound 1.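

In this assay a sulfur-linked tail on this carbonyl carbon sits level with the two fluorinated oxygen-linked tails, as shown by a number 4 percentage points lower from compound 3 to compound 4 (within the scatter) and by a number 8 percentage points lower from compound 2 to compound 4 (within the scatter) within the scatter. Compound 1 now stands apart from all three others, and the change to (tert-butyl)sulfanyl gives a number 21 percentage points lower from compound 1 to compound 4 (beyond the scatter) beyond the scatter. No measurement offered here accounts for this gap. As far as these compounds go, whether the nitrile or the oxygen link sets compound 1 apart stays open. A tert-butoxy tail or a (1-cyano-1-methylethyl)sulfanyl tail on the same carbonyl carbon would separate the two.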